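The compounds below may be only part of what the source reports. "The series", "measured", "known", "first", "only" and "open" are said of these compounds alone.

Measured so far in an ADME assay on RAW264.7 cells (Mus musculus) for cytotoxicity, read by MTT assay, with a stated time of 24 h, in the absence of a further agent; on this read-out higher numbers stand for weaker inhibition and lower numbers for stronger inhibition:
compound 1 `COc1cc(OC)c2c(c1)C(C(O)c1ccc(O)cc1)OC2=O` — > 40000 nM
compound 2 `CCCCOc1ccc(C(O)C2OC(=O)c3c(OC)cc(OC)cc32)cc1` — > 40000 nM
compound 3 `CCCCCCOc1ccc(C(O)C2OC(=O)c3c(OC)cc(OC)cc32)cc1` — > 40000 nM

Each of these three values is a limit of the assay and not a number; all three sit at the limit of > 40000 nM in this assay, at which 3 of the 3 values shown sit. Among the measured compounds shown here, compound 1 therefore has no place on a scale that can be read: its result is a limit, and the two further results are limits as well, so no compound can be set above or below another.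

Compound 4 `COc1cc(OC)c2c(c1)C(C(O)c1ccc(OCc3ccc(OC(F)F)cc3)cc1)OC2=O` has not yet been run in this assay. It differs from compound 1 in one place: 4-(difluoromethoxy)benzyl in place of hydrogen on an oxygen on an aromatic ring. The measured steps that bear on a change at this oxygen are a step that the two limits leave unreadable from compound 1 to compound 2 and a step that the two limits leave unreadable from compound 1 to compound 3; both leave the size of the step unreadable, since both ends sit at the limit. The change to compound 4 is larger than either, but nothing measured here distinguishes one substituent on this oxygen from another.

The expectation for compound 4 is therefore a result at or close to the limit, with a step of about a number no higher from compound 1 to compound 4 (the limit leaves the size open) from compound 1. Compound 4 is estimated at 40000 nM, within 15000 nM to 100000 nM.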

Compound 4, half-maximal inhibitory concentration: > 40000 nM
Compound 4: no number, only a limit; the forecaster's own chance of this, stated with the estimate: 75%; the middle value lies on the limit itself.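

In this assay compound 4 gives > 40000 nM, a limit and not a number. No new step can be read between compound 1, compound 2, compound 3 and compound 4, since all four results end at the same point: the limit of > 40000 nM in this assay, at which 4 of the 4 values shown sit.

The compounds shown leave open whether any substituent on this oxygen alters cytotoxicity, and at what concentration any of the four would inhibit.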